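Shifting a furan substituent in weak growth inhibitors

A few compounds are considered here, and "the series" means these few. Any claim that something is new, unique, unknown or untested is made for them only; others in the source may bear on it.

Compound 3 `COc1ccc(CNC(=O)/C(C#N)=C/c2cc(Br)co2)cc1` is, in a functional assay on DU-145 cells (Homo sapiens) for inhibition, read by MTT assay, with a stated time of 72 h (a higher number here means a weaker inhibitor of growth, a lower number a stronger inhibitor of growth), the highest of the two numbers that were reported: compound 3 gives 61000 nM. Its nearest neighbour is compound 2 `COc1ccc(CNC(=O)/C(C#N)=C/c2ccc(C)o2)cc1`, which in this assay gives 39000 nM; the step of a 1.6-fold higher number from compound 2 to compound 3 (0.19 log units; within the scatter) sits within the scatter. Compound 1 `COc1ccc(CNC(=O)/C(C#N)=C/c2ccc[nH]2)cc1` reaches only the limit of this assay, > 50000 nM, so it is a boundary and not a number (the limit of > 50000 nM in this assay, at which 1 of the 3 values shown sits). The step of an at least 1.2-fold lower number from compound 1 to compound 2 (0.10 log units; that floor lies within the scatter) is therefore of unreadable size at its floor.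

Compound 4 `COc1ccc(CNC(=O)/C(C#N)=C/c2ccoc2)cc1` differs from compound 3 in one place: furan-3-yl in place of 4-bromofuran-2-yl on a double-bonded chain carbon bound to a double-bonded chain carbon. The two measured steps that exchange one five-membered ring for another, a 1.6-fold higher number from compound 2 to compound 3 (0.19 log units; within the scatter) and an at least 1.2-fold lower number from compound 1 to compound 2 (0.10 log units; that floor lies within the scatter), both stayed inside the scatter, so no shift beyond the scatter is expected here either. Compound 4 is estimated at 50000 nM, with a range from 20000 nM to 130000 nM. This expected step, a 1.2-fold lower number from compound 3 to compound 4 (0.09 log units; within the scatter), means compound 4 would remain a weak inhibitor of growth, with a fair chance that this assay again reports only a limit.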

Compound 4, concentration for 50% growth inhibition: 7000 nM
Compound 4: middle estimate off by 7.1-fold (0.85 log units), on the high side, and the stated range ends above it.
By their numbers in this assay, from the lowest: compound 4; then compounds 2 and 3 (each within the scatter of the next).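

Compound 4 shows that this place on the shared core can respond to a ring change in this assay: the steps of an 8.7-fold lower number from compound 3 to compound 4 (0.94 log units; beyond the scatter) and a 5.6-fold lower number from compound 2 to compound 4 (0.75 log units; beyond the scatter) both lie beyond the scatter, unlike the step between compounds 2 and 3. Going by these compounds alone, the step of an at least 7.1-fold lower number from compound 1 to compound 4 (0.85 log units; beyond the scatter) gives only a floor, and the true size stays unknown because the value of compound 1 is a limit and not a number: the limit of > 50000 nM in this assay, at which 1 of the 4 values shown sits. Unlike the earlier compounds, compound 4 therefore reaches a value clearly separated from all the others.

Furan-3-yl differs from the other furans both in how the ring is attached and in carrying no bromine or methyl, so these steps cannot say which of the two matters. From the compounds shown here alone, whether an amine or a carboxylic acid on the furan-3-yl ring would keep the lower number also remains open.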